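The compounds below may be only part of what the source reports. "The series", "measured", "known", "first", "only" and "open" are said of these compounds alone.

Compound 1 `CCCCCCc1cnc(-c2cc3cn([C@H]4C[C@H](O)[C@@H](CO)O4)c(=O)nc3o2)nc1` gives > 100000 nM in an ADME assay on HEL cells (Homo sapiens) for cytotoxicity, with a stated time of 3 days (a lower number here means that less compound is tolerated, a higher number that more compound is tolerated), which is a limit of the assay rather than a number.
Compound 2 `CCCCCc1ccc(-c2cc3cn([C@H]4C[C@H](O)[C@@H](CO)O4)c(=O)nc3o2)cn1` gives 100000 nM in this assay.
Compound 3 `CCCC#Cc1ccc(-c2cc3cn([C@H]4C[C@H](O)[C@@H](CO)O4)c(=O)nc3o2)cn1` gives >= 100000 nM in this assay, again a limit rather than a number.

Among the compounds with values here, compound 3 thus stands at the upper edge of what the assay reports, and of the three values shown only the one for compound 2 is a plain number. Within the data shown here, the one measured step that touches compound 3 is a number no lower from compound 2 to compound 3 (the limit leaves the size open), where a chain with a triple bond replaced a saturated one; the reading for compound 3 is the limit of >= 100000 nM in this assay, at which 1 of the 3 values shown sits, so the size of that step cannot be read.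

Compound 4 `CCCCCCc1ccc(-c2cc3cn([C@H]4C[C@H](O)[C@@H](CO)O4)c(=O)nc3o2)cn1` is the target of the next step: hexyl in place of pent-1-yn-1-yl on an aromatic carbon. This roughly undoes the earlier swap of pentyl for pent-1-yn-1-yl and adds one carbon. Compound 1, which also carries a hexyl chain on a different ring, sits at the limit of > 100000 nM in this assay, at which 1 of the 3 values shown sits. Among the measured compounds shown here, since none of the measured compounds is found below the reporting limit, the step of a number no higher from compound 3 to compound 4 (the limit leaves the size open) is expected to stay within the scatter, and compound 4 is estimated at 100000 nM, in the range 50000 nM to 200000 nM, most likely reported only as a limit.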

Compound 4, minimum cytotoxic concentration: 100000 nM
Compound 4: middle estimate and measured number agree at the digits printed; the range from low to high includes it.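

Within the data shown here, with compound 4, this position on the six-membered aromatic ring with 1 nitrogen gives the first comparison between two plain numbers, and methyl in place of hydrogen on a saturated chain carbon, five bonds along the chain from an aromatic carbon, hexyl against pentyl, gives no change at the digits printed from compound 2 to compound 4 (within the scatter) in this assay. Tolerance of the compound in these cells therefore does not separate these two chain lengths at this position. The step with hexyl in place of pent-1-yn-1-yl on an aromatic carbon is a number no higher from compound 3 to compound 4 (the limit leaves the size open) and cannot be read, because the value of compound 3 is a limit: the limit of >= 100000 nM in this assay, at which 1 of the 4 values shown sits.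

The compounds shown leave open whether a much longer chain, such as dodecyl, would give a lower number in this assay. They also leave open what a chain ending in an amine or a carboxylic acid would give at this position.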